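Inverting one chain stereocentre in a short-lived pair

This account rests on a few compounds, and the source may have more. Where it says the series, first, only, none or still open, it means among the compounds named here.

In an in vitro ADME assay on microsomes from liver (Homo sapiens) for metabolic stability (a higher number here means that the compound lasts longer, a lower number that the compound disappears faster), compound 1 `CC(C)OCC1n2cncc2CN([C@@H](C)c2ccc(Cl)cc2)S1(=O)=O` gives 0.0833 h and compound 2 `CC(C)CC1n2cncc2CN([C@H](C)c2ccc(Cl)cc2)S1(=O)=O` gives 0.0833 h. For the measured compounds named here, the two values are level, so compound 2 stands with the only other measured compound, and no measured pair yet isolates a single structural change.

Compound 3 `CC(C)CC1n2cncc2CN([C@@H](C)c2ccc(Cl)cc2)S1(=O)=O` has the same atoms and bonds as compound 2: the two compounds have the same atoms and bonds; at least one stereo element is drawn with a configuration in one of them and without one in the other: 1 of 2 stereo elements differ; a stereocentre at a saturated chain carbon is drawn R in compound 2 and S in compound 3. The stereocentre concerned is at a saturated chain carbon, drawn R in compound 2 and S in compound 3.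

The data hold no measured inversion of this centre, so neither the size nor the direction of the step can be read from them. No step beyond the scatter is expected, and neither direction is favoured. The expected change is small: a 1.1-fold higher number from compound 2 to compound 3 (0.03 log units; within the scatter). For compound 3 the estimated half-life is 0.09 h, with an expected range from 0.05 h to 0.2 h.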

Compound 3, half-life: 0.1 h
Estimate against measurement, compound 3: 1.1-fold (0.05 log units) below, and the stated range covers the measured number.
By their numbers in this assay, from the lowest: compounds 1, 2 and 3 (each within the scatter of the next).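

In this assay, the stereocentre at the saturated chain carbon now has a measured single change, a 1.2-fold higher number from compound 2 to compound 3 (0.08 log units; within the scatter), so inverting this centre does not separate the two compounds beyond the scatter. The side chain also has its first measured single change, isopropyl in place of isopropoxy on a saturated chain carbon bound to a saturated ring carbon, with a 1.2-fold higher number from compound 1 to compound 3 (0.08 log units; within the scatter), again within the scatter. The reading of the stereocentre step carries one qualification: the fact that one of compounds 2 and 3 is drawn with a defined configuration and the other without, at the place where they differ

Still open, going by these compounds, is whether an amine or a carboxylic acid in place of isopropyl on that saturated chain carbon would move the half-life beyond the scatter. Also open, on these data alone, is whether the stereocentre stays without a visible effect when a longer chain stands there.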